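Chloro for hydrogen on two cores, one at the assay limit

A few compounds are considered here, and "the series" means these few. Any claim that something is new, unique, unknown or untested is made for them only; others in the source may bear on it.

Measured so far, in a functional assay on HCT-116 cells (Homo sapiens) for inhibition, read by MTT assay, with a stated time of 72 h; a higher number here means a weaker inhibitor, a lower number a stronger inhibitor:
Compound 1 `O=C1Nc2ccc(Cl)cc2/C1=N/NC(=S)N1CCN(c2ccccc2)CC1` gives 3490 nM.
Compound 2 `O=C1Nc2ccc(Cl)cc2/C1=N/NC(=S)N1CCN(c2ccc(Cl)cc2)CC1` gives 5390 nM.
Compound 3 `O=C1Nc2ccccc2/C1=N/NC(=S)Nc1ccccc1` gives > 100000 nM, which is a limit of the assay and not a number (the limit of > 100000 nM in this assay, at which 1 of the 3 values shown sits).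

Compound 1 and compound 2 differ by chloro in place of hydrogen on an aromatic carbon, and this step, a 1.5-fold higher number from compound 1 to compound 2 (0.19 log units; within the scatter), is within the scatter. Compound 4 `O=C1Nc2ccc(Cl)cc2/C1=N/NC(=S)Nc1ccccc1`, not yet measured, differs from compound 3 by chloro in place of hydrogen on an aromatic carbon; this is the same kind of change, not the same, since here the place is on a ring that is part of a fused or bridged system of two rings, meta and para to a fused ring, whereas in compound 2 it is para to a large group. The difference between the two cores is not broken down here. Since the same kind of change from compound 1 to compound 2 stayed within the scatter, compound 4 is expected to stay near the limit of compound 3, an expected step that the limit leaves unreadable from compound 3 to compound 4. Compound 4 is estimated at 150000 nM, expected between 40000 nM and 600000 nM.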

Compound 4, half-maximal inhibitory concentration: 30800 nM
Compound 4: middle estimate off by 4.9-fold (0.69 log units), on the high side; measured number below the stated range.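

In this assay, chloro in place of hydrogen on an aromatic carbon gave an at least 3.2-fold lower number from compound 3 to compound 4 (0.51 log units; beyond the scatter). This change therefore did not carry over with one size between these two cores, though the comparison does not separate the place of the chloro from the rest of the core: the same change on two cores in this assay, a 1.5-fold higher number (0.19 log units; within the scatter) from compound 1 to compound 2 and an at least 3.2-fold lower number (0.51 log units; beyond the scatter) from compound 3 to compound 4, at least 5.0-fold (0.70 log units) apart, beyond the scatter of two such steps. Compound 3 stands at a limit of the assay, so the step from it gives only a minimum size: the limit of > 100000 nM in this assay, at which 1 of the 4 values shown sits.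

The compounds shown leave open whether fluoro, bromo or methyl in the same place would follow either step. They also leave open how the chloro on the fused ring acts within the core of compound 1.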